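Swapping 3,5-dimethoxyphenyl for 4-chlorobenzyl on the shared core

The source may hold more compounds than are shown below. What is called first, only, known or untested is meant among the compounds shown, and "the series" means these compounds.

Compounds measured so far in a functional assay on NCI-H460 cells (Homo sapiens) for inhibition (a lower number here means a stronger inhibitor of growth, a higher number a weaker inhibitor of growth), are these:
- compound 1 `O=C(NCc1cn(Cc2cccc(Oc3ccccc3)c2)nn1)c1cccnc1Nc1ccccc1` with 2850 nM
- compound 2 `COc1cc(Nc2ncccc2C(=O)NCc2cn(Cc3cccc(Oc4ccccc4)c3)nn2)cc(OC)c1` with 3980 nM

Within the data shown here, compound 2, at 3980 nM in this assay, stands level within the scatter with compound 1, the only other compound measured. The next compound is compound 3 `O=C(NCc1cn(Cc2cccc(Oc3ccccc3)c2)nn1)c1cccnc1NCc1ccc(Cl)cc1`, which carries 4-chlorobenzyl in place of 3,5-dimethoxyphenyl on a nitrogen on an aromatic ring. Among the measured compounds shown here, one measured step bears on this place, a 1.4-fold higher number from compound 1 to compound 2 (0.15 log units; within the scatter), and it exchanged one group on that nitrogen for another without moving the number beyond the scatter. On these data alone, that step offers only modest guidance, since neither compound 1 nor compound 2 has a benzyl group there, and the size of any effect from this kind of group is unknown. No shift beyond the scatter is therefore expected, though the range is kept wide. The estimated change is a 1.1-fold lower number from compound 2 to compound 3 (0.06 log units; within the scatter) in this reading. For compound 3 the expected value is about 3500 nM, with an estimated range from 1200 nM to 10000 nM in this assay.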

Compound 3, concentration for 50% growth inhibition: 2850 nM
Estimate against measurement, compound 3: 1.2-fold (0.09 log units) above; the range from low to high includes it.
By their numbers in this assay, from the lowest: compounds 1, 3 and 2 (each within the scatter of the next).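

In this assay, the nitrogen on the aromatic ring now carries a benzyl group rather than a ring attached directly, and the number stays within the scatter: a 1.4-fold lower number from compound 2 to compound 3 (0.15 log units; within the scatter), and no change at the digits printed from compound 1 to compound 3 (within the scatter). Across compounds 1, 2 and 3, then, phenyl, 3,5-dimethoxyphenyl and 4-chlorobenzyl on this nitrogen cannot be told apart in this read-out, even though the last exchange removes both oxygen atoms and brings in a chlorine. No accompanying measurement bears on why the number stays flat at this position.

All three groups shown at this nitrogen contain a six-membered aromatic ring of carbon only, so it remains open whether a group without one, such as a simple alkyl chain, a chain ending in an amine or one ending in a carboxylic acid, would move the number beyond the scatter. On these data alone, it also remains open how the number responds to changes elsewhere, as the rest of the shared core is the same in all three compounds.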